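A few compounds are considered here, and "the series" means these few. Any claim that something is new, unique, unknown or untested is made for them only; others in the source may bear on it.

Measured so far:
- compound 1, `C=CC(=C)CC[C@@H]1[C@@]2(C)CCC[C@](C)(COC(=O)/C=C\c3ccc(O)cc3)[C@@H]2CC[C@@]1(C)O`: 17100 nM
- compound 2, `C=C1CC[C@@H]2[C@](C)(CCC[C@]2(C)C(=O)O)[C@H]1CC/C(C)=C/CO`: > 40000 nM, a limit of the assay
- compound 3, `C=C[C@@]1(C)O[C@H]1C[C@H]1C(=C)CC[C@@H]2[C@]1(C)CCC[C@]2(C)C(=O)O`: > 40000 nM, a limit of the assay

Among the compounds with values here, in a functional assay on A549 cells (Homo sapiens) for cytotoxicity, read by MTT assay, with a stated time of 48 h (a higher number here means a weaker inhibitor, a lower number a stronger inhibitor), compound 1 gives 17100 nM, the only true number among the three. Compound 2 reaches only the limit > 40000 nM. Compound 3 likewise stops at the limit > 40000 nM, as noted in the limit of > 40000 nM in this assay, at which 2 of the 3 values shown sit. Within the data shown here, the one step between measured compounds, a step that the two limits leave unreadable from compound 2 to compound 3, concerns a different part of the molecule and cannot be read.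

Compound 4, `C=CC(=C)CC[C@@H]1[C@@]2(C)CCC[C@](C)(COC(=O)/C=C/c3ccc(O)c(OC)c3)[C@@H]2CC[C@@]1(C)O`, differs from compound 1 in one place: 2-(4-hydroxy-3-methoxyphenyl)ethenyl in place of 2-(4-hydroxyphenyl)ethenyl on a carbonyl carbon. Among the measured compounds shown here, no measured step bears on this change. No shift beyond the usual scatter is therefore expected, and the estimated step is a 1.0-fold lower number from compound 1 to compound 4 (0.00 log units; within the scatter). Compound 4 is expected to give 17000 nM, within a range from 6000 nM to 45000 nM.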

Compound 4, half-maximal inhibitory concentration: 16800 nM
Compound 4: middle estimate off by 1.0-fold (0.01 log units), on the high side; measured number inside the range.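

In this assay the swap to 2-(4-hydroxy-3-methoxyphenyl)ethenyl gives a 1.0-fold lower number from compound 1 to compound 4 (0.01 log units; within the scatter) and so is the first step among these compounds that can be read. This place on the carbonyl carbon therefore accepts the extra methoxy group with no shift beyond the usual scatter. No measurement shown gives a cause for this result.

On these data alone, whether an amine, a carboxylic acid or a longer chain in place of that methoxy group would move the number stays open. Also open, as far as these compounds go, is whether any change to this aromatic ring can shift the number beyond the scatter.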